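This account rests on a few compounds, and the source may have more. Where it says the series, first, only, none or still open, it means among the compounds named here.

Measured compounds:
- Compound 1, `COc1cc(/C=C/C(=O)Nc2nc(-c3c(C)cc(C)cc3C)cs2)cc(OC)c1OC`: 11800 nM
- Compound 2, `Cc1ccc(/C=C/C(=O)Nc2nc(-c3c(C)cc(C)cc3C)cs2)cc1`: 7880 nM
- Compound 3, `Cc1cc(C)c(-c2csc(NC(=O)/C=C/c3ccc(Cl)c(C(F)(F)F)c3)n2)c(C)c1`: 3060 nM

All three share the same core and differ only in the aryl group attached to the double-bonded chain. In a functional assay on K562 cells (Homo sapiens) for inhibition, read by MTT assay, with a stated time of 96 h (on this read-out lower numbers stand for stronger inhibition and higher numbers for weaker inhibition), compound 2 gives 7880 nM, the second highest of the three numbers. Compound 1 gives 11800 nM in this assay, which is within the scatter of the number for compound 2, so the two cannot be separated. Compound 3 gives 3060 nM, a lower number than compound 2 by a margin beyond the scatter.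

Compound 4, `Cc1cc(C)c(-c2csc(NC(=O)/C=C/c3ccncc3)n2)c(C)c1`, has not yet been measured in this assay. It differs from compound 2 by pyridin-4-yl in place of 4-methylphenyl on a double-bonded chain carbon bound to a double-bonded chain carbon. Within the data shown here, no directly comparable step between measured compounds exists in this set, so the size and direction of the change can only be guessed from the spread of the three numbers at hand. The replacement of an all-carbon ring by a ring with one hetero atom is expected to leave the number near that of compound 2 or to raise it somewhat; the estimated step of a 1.5-fold higher number from compound 2 to compound 4 (0.18 log units; within the scatter) is expected to be small and toward weaker inhibition. Compound 4 is therefore estimated at 12000 nM, with a range from 4000 nM to 40000 nM.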

Compound 4, half-maximal inhibitory concentration: 9390 nM
Estimate against measurement, compound 4: 1.3-fold (0.11 log units) above, within the range that was stated.
By their numbers in this assay, from the lowest: compound 3; then compounds 2, 4 and 1 (each within the scatter of the next).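

Notes on the aryl position: the series now has its first comparison of compounds that differ in one place. In this assay, pyridin-4-yl in place of 4-methylphenyl gives a 1.2-fold higher number from compound 2 to compound 4 (0.08 log units; within the scatter), so at this position on the double-bonded chain carbon, a six-membered aromatic ring with a nitrogen reads the same as the all-carbon ring carrying a methyl group. No measurement at hand offers an explanation for this outcome.

The exchange removes the methyl group and introduces the nitrogen in a single step, so the compounds shown cannot separate any contribution from either change, and opposing contributions cannot be ruled out. Also open, from the compounds shown here alone, is how this position responds to a phenyl ring carrying an amine or a carboxylic acid, or to a saturated ring such as piperidine in place of the aromatic ring.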